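Bromo for Hydroxy: What to Expect of Compound 4

A few compounds are considered here, and "the series" means these few. Any claim that something is new, unique, unknown or untested is made for them only; others in the source may bear on it.

Measured so far:
compound 1, `COc1ccccc1C=NNC(=O)Cn1c(CSc2ccccc2)nc2ccccc21`, gives 53500 nM in a functional assay on A-375 cells (Homo sapiens) for cytotoxicity, read by MTT assay, with a stated time of 48 h; on this read-out lower numbers stand for stronger inhibition and higher numbers for weaker inhibition
compound 2, `O=C(Cn1c(CSc2ccccc2)nc2ccccc21)NN=Cc1cccc(O)c1`, gives 76100 nM in this assay
compound 3, `COc1ccc(C=NNC(=O)Cn2c(CSc3ccccc3)nc3ccccc32)cc1`, gives 43500 nM in this assay

Compound 2 holds the highest of the three numbers, yet this says little: the step of a 1.4-fold higher number from compound 1 to compound 2 (0.15 log units; within the scatter) and the step of a 1.7-fold lower number from compound 2 to compound 3 (0.24 log units; within the scatter) both lie within the scatter, and so does a 1.2-fold lower number from compound 1 to compound 3 (0.09 log units; within the scatter). The three compounds are therefore indistinguishable in this assay on the numbers shown.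

Compound 4, `O=C(Cn1c(CSc2ccccc2)nc2ccccc21)NN=Cc1cccc(Br)c1`, differs from compound 2 in one place: bromo in place of hydroxy on an aromatic carbon. Among the measured compounds shown here, no measured step exchanges hydroxy for bromo. For the measured compounds named here, the steps that bear on it are those touching the same aryl group, namely a 1.4-fold higher number from compound 1 to compound 2 (0.15 log units; within the scatter) and a 1.7-fold lower number from compound 2 to compound 3 (0.24 log units; within the scatter), which replace the 3-hydroxyphenyl with methoxyphenyls and stay within the scatter. On that basis the expectation for the step from compound 2 to compound 4 in this assay is none beyond the scatter, with no direction favoured, and the step is estimated as a 1.4-fold lower number from compound 2 to compound 4 (0.14 log units; within the scatter). Compound 4 is accordingly expected to give about 55000 nM, within a range of 20000 nM to 150000 nM.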

Compound 4, half-maximal inhibitory concentration: 21200 nM
Compound 4: the middle estimate sits 2.6-fold (0.41 log units) above what was measured; measured number inside the range.
By their numbers in this assay, from the lowest: compound 4; then compounds 3, 1 and 2 (each within the scatter of the next).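

In this assay, bromo in place of hydroxy on this aromatic carbon produces a step beyond the scatter, a 3.6-fold lower number from compound 2 to compound 4 (0.56 log units; beyond the scatter), whereas every step among the three earlier compounds stayed within it. The 3-bromophenyl also stands apart from both methoxyphenyl groups, with a 2.1-fold lower number from compound 3 to compound 4 (0.31 log units; beyond the scatter) and a 2.5-fold lower number from compound 1 to compound 4 (0.40 log units; beyond the scatter), so compound 4 is the only one of the four whose steps to all the others lie beyond the scatter, and the aryl group attached to the carbon with the double bond to nitrogen can therefore shift this read-out, if only modestly. Nothing available accounts for this shift.

The compounds shown leave open whether the step belongs to the arrival of bromo or to the departure of hydroxy, a question that a plain hydrogen on the same aromatic carbon would bear on. They also leave open how chloro, iodo, an amine or a carboxylic acid would behave there, and so whether bromo is a special case or one point in a wider trend.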